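This account rests on a few compounds, and the source may have more. Where it says the series, first, only, none or still open, it means among the compounds named here.

Measured compounds in a functional assay on a cell-free system (plasma, Oryctolagus cuniculus) for inhibition, with stated times of 5 min, 1 min and 6 min; on this read-out higher numbers stand for weaker inhibition and lower numbers for stronger inhibition:
- compound 1, `CCOC(=O)COn1c(-c2cccc(C#N)c2)nc(C)c1C(=O)OCC`: 6800 nM
- compound 2, `CCOC(=O)c1c(C)nc(-c2cccc(C#N)c2)n1OCC(N)=O`: a limit of the assay, > 30000 nM
- compound 3, `CCOC(=O)c1c(C)nc(-c2cccc(C#N)c2)n1OCc1ccccc1`: 5930 nM

Compound 1 gives the highest of the two numbers reported in this assay, though its nearest neighbour, compound 3, lies within the usual scatter of it. Compound 2 is known only through a limit of > 30000 nM in this assay, at which 1 of the 3 values shown sits, and not through a number.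

Compound 4, `CCOC(=O)c1c(C)nc(-c2cccc(C#N)c2)n1OCc1ccc(Br)cc1`, has not been measured. It differs from compound 1 in one place: 4-bromophenyl in place of ethoxycarbonyl on a saturated chain carbon bound to an oxygen on an aromatic ring.

Among the measured compounds shown here, one measured step bears directly on this change. Going a 1.1-fold lower number from compound 1 to compound 3 (0.06 log units; within the scatter), the exchange of the ethoxycarbonyl for a phenyl on the same carbon left the number essentially unchanged. The other steps, an at least 4.4-fold higher number from compound 1 to compound 2 (0.64 log units; beyond the scatter) and an at least 5.0-fold lower number from compound 2 to compound 3 (0.70 log units; beyond the scatter), concern the carbamoyl and stand further from the present change. Since compound 4 carries a 4-bromophenyl where compound 3 carries a phenyl, the step to compound 4 is expected to look like the step to compound 3: no change beyond the scatter, a 1.5-fold lower number from compound 1 to compound 4 (0.18 log units; within the scatter).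

Compound 4 is therefore estimated to give 4500 nM in this assay, with a likely range from 1500 nM to 13000 nM.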

Compound 4, half-maximal inhibitory concentration: 24600 nM
The estimate for compound 4 lay 5.5-fold (0.74 log units) below the measured number; the measured number lies above the stated range.
By their numbers in this assay, from the lowest: compounds 3 and 1 (each within the scatter of the next); then compound 4. At a limit, above all of these: compound 2.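

Compound 3 had suggested that this saturated chain carbon accepts a phenyl in place of ethoxycarbonyl with no change in this assay, but that no longer holds once the ring carries bromo (a 3.6-fold higher number from compound 1 to compound 4 (0.56 log units; beyond the scatter)). The clearest new finding is that bromo in place of hydrogen on an aromatic carbon is enough on its own to move the number beyond the scatter (a 4.1-fold higher number from compound 3 to compound 4 (0.62 log units; beyond the scatter)), so the outcome at this position depends on the substituent on the incoming phenyl and not only on the loss of the ethoxycarbonyl. The comparison with the carbamoyl compound rests on a limit of the assay, and its floor does not separate the two (an at least 1.2-fold lower number from compound 2 to compound 4 (0.08 log units; that floor lies within the scatter)): the limit of > 30000 nM in this assay, at which 1 of the 4 values shown sits.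

The compounds shown leave open whether the higher number is specific to bromo or would also appear with a chloro, a methoxy or an amine on the same ring, as only hydrogen and bromo can be compared there. They also leave open how a carboxylic acid in place of the ethoxycarbonyl, or a longer chain carrying the 4-bromophenyl, would read in this assay.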